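Phenyl on the ring nitrogen of a diaryl pyridinone core

A few compounds are considered here, and "the series" means these few. Any claim that something is new, unique, unknown or untested is made for them only; others in the source may bear on it.

Measured so far:
compound 1, `O=c1ccc(-c2ccccc2)cn1-c1ccccc1`, 0.114 mL.min-1.g-1
compound 2, `O=c1[nH]cc(-c2ccccc2)cc1-c1ccccc1`, 0.371 mL.min-1.g-1

Of the compounds shown here, two have been measured in an in vitro ADME assay on microsomes from liver (Homo sapiens) for metabolic stability, read by LC-MS, with a stated time of 15 min; a higher number here means faster removal of the compound, a lower number slower removal. Compound 1 gives 0.114 mL.min-1.g-1. Compound 2 gives 0.371 mL.min-1.g-1, the higher of the two numbers; the gap between compound 1 and compound 2 lies beyond the usual scatter, but the two structures differ in more than one place, so the gap cannot be tied to a single change.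

Compound 3, `O=c1c(-c2ccccc2)cc(-c2ccccc2)cn1-c1ccccc1`, has not yet been measured. It arises from compound 2 by the change (phenyl in place of hydrogen on an aromatic nitrogen). Among the compounds with values here, no single-point comparison among the measured compounds resembles this change, so there is no measured step to lean on. In this assay compound 3 is expected to land close to compound 2, with a modest shift upward at most, so that the step from compound 2 to compound 3 is estimated as a 1.3-fold higher number from compound 2 to compound 3 (0.13 log units; within the scatter), not clearly beyond the scatter. The estimate for compound 3 in this assay is 0.5 mL.min-1.g-1, within a range from 0.2 mL.min-1.g-1 to 1.2 mL.min-1.g-1.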

Compound 3, intrinsic clearance in microsomes: 0.045 mL.min-1.g-1
Estimate against measurement, compound 3: 11-fold (1.05 log units) above; the whole stated range lies above it.
By their numbers in this assay, from the lowest: compound 3; then compound 1; then compound 2.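

In this assay, within the data shown here, the single change of phenyl in place of hydrogen on an aromatic nitrogen gives an 8.2-fold lower number from compound 2 to compound 3 (0.92 log units; beyond the scatter) and so shows for the first time what this position does to the number when it alone is altered, a clear fall rather than a rise. The other single change, phenyl in place of hydrogen on an aromatic carbon, points the same way with a 2.5-fold lower number from compound 1 to compound 3 (0.40 log units; beyond the scatter) and is also beyond the scatter, so within these three compounds each added phenyl group comes with a lower number and neither step goes against that. Nothing measured here tells what lies behind either fall.

The compounds shown leave open whether the fall at the nitrogen belongs to phenyl itself or would also appear with another group in that place, such as methyl, a longer chain or a pyridyl ring. They also leave open how far the low number of compound 3 would hold if the phenyl on the nitrogen carried a substituent such as an amine or a carboxylic acid.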